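Swapping Fluorines for Chlorines on the Sulfonyl Aryl Group

The compounds below may be only part of what the source reports. "The series", "measured", "known", "first", "only" and "open" are said of these compounds alone.

In an ADME assay on microsomes from liver (Homo sapiens) for metabolic stability, tested at 2.5 uM (a lower number here means slower removal, a higher number faster removal of the compound), compound 2 `COc1cccc(-c2c(S(=O)(=O)c3cc(F)cc(F)c3)cnc3cc(F)ccc23)c1` gives 1.81 mL/min, and compound 1 `COc1ccc(-c2c(S(=O)(=O)c3cc(F)cc(F)c3)cnc3cc(F)ccc23)cc1` gives 1.51 mL/min; the two stand within the scatter of each other, as a 1.2-fold higher number from compound 1 to compound 2 (0.08 log units; within the scatter) shows. Compound 3 `COc1cccc(-c2c(S(=O)(=O)c3cc(Cl)cc(Cl)c3)cnc3cc(F)ccc23)c1` differs from compound 2 in one place: 3,5-dichlorophenyl in place of 3,5-difluorophenyl on a sulfonyl sulfur. Within the data shown here, no measured step touches the group on the sulfonyl sulfur, so nothing measured here bears directly on this change. Compound 3 is therefore expected to give about 2.2 mL/min (range 1 mL/min to 5 mL/min) in this assay. The step of a 1.2-fold higher number from compound 2 to compound 3 (0.08 log units; within the scatter) is expected to stay within the scatter.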

Compound 3, intrinsic clearance in a liver preparation (reported as CLH), per the amount of preparation that the assay uses: 1.51 mL/min
For compound 3 the middle estimate is 1.5-fold (0.16 log units) above the measured one; low and high end bracket the measured number.
By their numbers in this assay, from the lowest: compounds 1, 3 and 2 (each within the scatter of the next).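

Among these compounds, putting 3,5-dichlorophenyl in place of 3,5-difluorophenyl on a sulfonyl sulfur in this assay gives a 1.2-fold lower number from compound 2 to compound 3 (0.08 log units; within the scatter) and is the first measured change at this position. Exchanging these two halogens therefore leaves the read-out within the scatter in this one pair. No measured evidence here offers an explanation for this result. The compounds shown leave open whether the number would hold with an amine or a carboxylic acid on this aryl ring. They also leave open what a longer chain on the sulfonyl sulfur would give in place of the ring.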